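Capping a Ring Hydroxy with Methyl: Expected Cytotoxicity

A few compounds are considered here, and "the series" means these few. Any claim that something is new, unique, unknown or untested is made for them only; others in the source may bear on it.

Compound 1 `COc1cc(/C=C/C(=O)Oc2ccc(OCc3c(-c4ccccc4)no[n+]3[O-])cc2)ccc1O` gives > 50000 nM
Compound 2 `O=C(/C=C/c1ccc(OCCCCCCO[N+](=O)[O-])c(O)c1)OCCCCCCO[N+](=O)[O-]` gives > 50000 nM
Compound 3 `COc1cc(/C=C/C(=O)OCCCO[N+](=O)[O-])ccc1O` gives 44000 nM

All three were tested in a functional assay on H266 cells (Homo sapiens) for cytotoxicity, read by resazurin assay, with a stated time of 72 h; a higher number here means a weaker inhibitor, a lower number a stronger inhibitor. For compound 2 the value > 50000 nM is a limit of the assay, not a measured number. Compound 1 likewise sits at a limit with > 50000 nM. Compound 3 gives an actual number, 44000 nM, which is a weak inhibition.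

Compound 4 `COc1cc(/C=C/C(=O)OCCCCCCO[N+](=O)[O-])ccc1OCCCCCCO[N+](=O)[O-]` is not yet measured. It differs from compound 2 by methyl in place of hydrogen on an oxygen on an aromatic ring, that is hydroxy to methoxy. Going by the values given here, no measured pair differs in only one place, so the size of this step cannot be read from the data. Given (the limit of > 50000 nM in this assay, at which 2 of the 3 values shown sit), no move beyond the scatter is expected, and a limit is the most likely outcome again. Compound 4 is expected at 60000 nM, within 25000 nM to 150000 nM. The expected step that the limit leaves unreadable from compound 2 to compound 4 is essentially none.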

Compound 4, half-maximal inhibitory concentration: > 50000 nM
Compound 4: only a limit was reported (the forecaster's own chance of this, stated with the estimate: 70%); the middle value lies beyond the limit too.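

The step from compound 2 to compound 4 cannot be read because both compounds give only a limit, not a measured number: the limit of > 50000 nM in this assay, at which 3 of the 4 values shown sit.

From the compounds shown here alone, whether changing hydroxy to methoxy alters cytotoxicity at all remains open.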